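Ring amide nitrogen: amino for methyl, series notes

This account rests on a few compounds, and the source may have more. Where it says the series, first, only, none or still open, it means among the compounds named here.

Measured in a functional assay on the whole organism (strain Swiss albino) for inhibition, with Mus musculus as the target, in the maximal electroshock model, with a stated time of 2 h, at a dose of 25 mg/kg by the intraperitoneal route; a higher number here means more inhibition at the dose given (going by the name of the read-out), a lower number less inhibition:
compound 1 `Cc1ccccc1N1C(=O)C(c2ccccc2)CC(c2ccccc2)C1=O`: 66.1%
compound 2 `O=C1NC(=O)C(c2ccccc2Cl)CC1c1ccccc1Cl`: 58.3%
compound 3 `CN1C(=O)C(c2ccccc2Cl)CC(c2ccccc2Cl)C1=O`: 61.7%

Compound 3 stands second of the three numbers, all three within the scatter of one another; its nearest neighbour is compound 2, with a number 3.4 percentage points higher from compound 2 to compound 3 (within the scatter), and compound 1 lies on the other side by a gap also within the scatter.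

Compound 4 `NN1C(=O)C(c2ccccc2Cl)CC(c2ccccc2Cl)C1=O` differs from compound 3 by amino in place of methyl on an amide-type nitrogen in a ring. Among the compounds with values here, the only measured step at this position is a number 3.4 percentage points higher from compound 2 to compound 3 (within the scatter), a change of substituent on the same ring amide nitrogen that left the read-out within the scatter. Within the data shown here, no measured step introduces an amino group anywhere. For compound 4 the step of a number 1.7 percentage points lower from compound 3 to compound 4 (within the scatter) is therefore expected to stay within the scatter, in no clear direction. Compound 4 is estimated at 60%, range 45% to 75%.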

Compound 4, a percentage reported as inhibition, in the whole organism at one dose (the size of the read-out at that dose, not a potency): 73.3%
Compound 4: the middle estimate sits 13.3 percentage points below what was measured, within the range that was stated.
By their numbers in this assay, from the lowest: compounds 2, 3, 1 and 4 (each within the scatter of the next, the first and the last beyond it).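

In this assay the substituent on the ring amide nitrogen can move the read-out beyond the scatter: amino in place of methyl gives a number 11.6 percentage points higher from compound 3 to compound 4 (beyond the scatter) and amino in place of hydrogen gives a number 15 percentage points higher from compound 2 to compound 4 (beyond the scatter) at this position. The earlier methyl in place of hydrogen step on this nitrogen gave a number 3.4 percentage points higher from compound 2 to compound 3 (within the scatter) and so did not show this. Nothing available accounts for the difference between amino and methyl here.

From the compounds shown here alone, whether a hydroxyl or methylamino group on the same nitrogen would match amino remains open. Also open, going by these compounds, is whether the step holds when the two 2-chlorophenyl groups are replaced by plain phenyl.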